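Triazole-Linked Bicyclic Lactams Tested on Pancreatic Cancer Cells

The source may report more compounds than this note shows. Statements on the series, on what has been measured and on what is new or still open speak of the compounds shown alone.

The measured compounds and their values:
Compound 1, `COc1ccccc1-n1cc(CN2C(=O)C[C@@H]3CC[C@@]2(C)C3(C)C)nn1` — 120 nM
Compound 2, `COc1ccc(-n2cc(CN3C(=O)C[C@@H]4CC[C@@]3(C)C4(C)C)nn2)cc1` — 330 nM
Compound 3, `CC1(C)[C@H]2CC[C@]1(C)N(Cc1cn(-c3cccc(Br)c3)nn1)C(=O)C2` — 90 nM

These three compounds share a common core and differ only in the aryl group carried on an aromatic nitrogen of the triazole. In a functional assay on PANC-1 cells (Homo sapiens) for inhibition, read by MTT assay, with a stated time of 24 h (on this read-out higher numbers stand for weaker inhibition and lower numbers for stronger inhibition), compound 1 gives 120 nM, compound 2 gives 330 nM and compound 3 gives 90 nM. Compound 3 has the lowest number of the three, but its distance from compound 1 is within the scatter, so the two cannot be ordered; only compound 2 stands clearly apart, with a 3.7-fold lower number from compound 2 to compound 3 (0.56 log units; beyond the scatter). The step of a 1.3-fold lower number from compound 1 to compound 3 (0.12 log units; within the scatter) shows that swapping a 2-methoxyphenyl for a 3-bromophenyl hardly moves the read-out.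

Compound 4, `CC1(C)[C@H]2CC[C@]1(C)N(Cc1cn(-c3ccccc3Cl)nn1)C(=O)C2`, is the next compound. 2-chlorophenyl in place of 3-bromophenyl on an aromatic nitrogen Both steps that end at compound 3 bear on this change: compound 1, which also carries a group at the same ring position as the incoming 2-chlorophenyl, sits within the scatter of compound 3, while compound 2 lies a modest distance away. Compound 4 is therefore expected to fall close to compound 3, with a 1.2-fold higher number from compound 3 to compound 4 (0.09 log units; within the scatter) likely within the scatter. The estimated value for compound 4 is 110 nM, with a range from 50 nM to 250 nM.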

Compound 4, half-maximal inhibitory concentration: 270 nM
Compound 4: middle estimate off by 2.5-fold (0.39 log units), on the low side; measured number outside the range, above it.
By their numbers in this assay, from the lowest: compounds 3 and 1 (each within the scatter of the next); then compounds 4 and 2 (each within the scatter of the next).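

Among the compounds shown here, the step from compound 1 to compound 4 is the first that swaps one substituent on the aryl ring, a chloro in place of a methoxy, and in this assay that single swap lies beyond the scatter (a 2.3-fold higher number from compound 1 to compound 4 (0.35 log units; beyond the scatter)). The change from the 3-bromophenyl to the 2-chlorophenyl is also beyond the scatter (a 3.0-fold higher number from compound 3 to compound 4 (0.48 log units; beyond the scatter)), which shows that carrying a halogen on the aryl ring does not by itself keep a compound level with compound 3, while the 2-chlorophenyl cannot be told apart from the 4-methoxyphenyl (a 1.2-fold lower number from compound 2 to compound 4 (0.09 log units; within the scatter)). No supporting measurement is available to explain these shifts.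

From compound 3 to compound 4 the halogen and its place on the ring change together, and the compounds shown cannot separate the two contributions. Also open, on these data alone, is how the read-out would respond to an unsubstituted phenyl, or to a phenyl carrying an amine or a carboxylic acid, on the same aromatic nitrogen of the shared core.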